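This account rests on a few compounds, and the source may have more. Where it says the series, first, only, none or still open, it means among the compounds named here.

Working notes on the series, read in a physicochemical assay for lipophilicity; on this read-out lower numbers stand for lower lipophilicity and higher numbers for higher lipophilicity. In this assay compound 1 `C/C=C/C=C/C(N)=O` gives 0.6, and compound 2 `C/C=C/C=C/C(=O)NN` gives 0.59. Among the compounds with values here, the one measured step in a single place is a number 0.01 log units lower from compound 1 to compound 2 (within the scatter), with amino in place of hydrogen on an amide-type nitrogen. Compound 3 `C/C=C/C=C/C(=O)OC(C)C` stands highest of the three at 2.26, beyond the scatter from both others.

The next structure is compound 4 `C=CCOC(=O)/C=C/C=C/C`, and the change is allyl in place of isopropyl on an oxygen next to a carbonyl group. The step of a number 0.01 log units lower from compound 1 to compound 2 (within the scatter) lies at a different place and involves different groups, so it bears on this change only loosely. The gaps between compound 3 and the other two compounds are not single-place steps of this kind. Within the data shown here, no measurement yet covers this exchange, so the expectation is anchored on compound 3 at 2.26 and allows for only a small downward move in this assay. The expected step is a number 0.26 log units lower from compound 3 to compound 4 (within the scatter). For compound 4 the estimate is 2, with an expected range from 1.7 to 2.3.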

Compound 4, partition coefficient: 2.24
Compound 4: middle estimate off by 0.24 log units, on the low side, within the range that was stated.
By their numbers in this assay, from the lowest: compounds 2 and 1 (each within the scatter of the next); then compounds 4 and 3 (each within the scatter of the next).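

Within the data shown here, this is the first single-place step at this position, on an oxygen next to a carbonyl group: in this assay, allyl in place of isopropyl gives a number 0.02 log units lower from compound 3 to compound 4 (within the scatter). The two groups have the same count of 3 heavy atoms (3 carbon), and allyl brings 1 double bond outside aromatic rings, so at this place, in this pair, that difference in the entering group gives a step inside the scatter, as does the step at the other measured place, a number 0.01 log units lower from compound 1 to compound 2 (within the scatter), on an amide-type nitrogen. No measured information is available to explain why isopropyl and allyl read alike here.

The compounds shown leave open how a longer chain such as octyl, a benzyl group or the free carboxylic acid would read at this place in this assay, and so how far this pair speaks for groups of a different size or kind. They also leave open whether allyl in place of isopropyl would give a step of similar size at the amide-type nitrogen of compound 1.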